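The compounds below may be only part of what the source reports. "The series", "measured", "known", "first", "only" and "open" are said of these compounds alone.

Measured in a functional assay on MOLT-4 cells (Homo sapiens) for antiproliferative activity; a lower number here means a stronger inhibitor, a higher number a weaker inhibitor:
compound 1 `COc1cc(C(=O)c2sc(-c3ccncc3)cc2N)cc(OC)c1OC`: 88 nM
compound 2 `COc1cc(C(=O)c2sc(-c3ccsc3)cc2N)cc(OC)c1OC`: 8.8 nM

Among the measured compounds shown here, compound 2 holds the lower of the two numbers so far. For the measured compounds named here, the one measured step is a 10-fold lower number from compound 1 to compound 2 (1.00 log units; beyond the scatter), with thiophen-3-yl in place of pyridin-4-yl on an aromatic carbon. It is modest in size but beyond the scatter, and it shows that the group at this carbon can move the number.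

Compound 3 `CCOc1ccc(-c2cc(N)c(C(=O)c3cc(OC)c(OC)c(OC)c3)s2)cc1` keeps the shared core and changes the same group: 4-ethoxyphenyl in place of thiophen-3-yl on an aromatic carbon. The 4-ethoxyphenyl group stands in place of thiophen-3-yl, next to the ring sulfur. Going by the values given here, no measured compound carries it, so the data do not fix the direction, and one step is thin support for any size. Compound 2 at 8.8 nM is the lowest value yet seen, so a moderately higher number is the working expectation in this assay. The expected step is a 2.3-fold higher number from compound 2 to compound 3 (0.36 log units; beyond the scatter), smaller than the measured one. For compound 3 the estimated value is 20 nM, with an expected range of 5 nM to 90 nM.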

Compound 3, half-maximal inhibitory concentration: 240 nM
For compound 3 the middle estimate is 12-fold (1.08 log units) below the measured one; measured number above the stated range.
By their numbers in this assay, from the lowest: compound 2; then compound 1; then compound 3.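

In this assay the group on this aromatic carbon, next to the ring sulfur, carries more weight than the first pair showed: there is a 27-fold higher number from compound 2 to compound 3 (1.44 log units; beyond the scatter) with 4-ethoxyphenyl in place of thiophen-3-yl, a large change where the earlier one was modest. The new group also falls behind pyridin-4-yl, with a 2.7-fold higher number from compound 1 to compound 3 (0.44 log units; beyond the scatter), so the three groups now rank thiophen-3-yl, pyridin-4-yl, 4-ethoxyphenyl, from the lowest number to the highest, and the largest group, at 9 heavy atoms against 5 for thiophen-3-yl, sits at the high end in these three compounds only. Nothing measured alongside these compounds accounts for the size of either step.

From the compounds shown here alone, it remains open whether the higher number of compound 3 belongs to the ethoxy chain or to the carbon-only ring itself, a separation that plain phenyl or 4-methoxyphenyl at this carbon would allow. Also open, going by these compounds, is whether the low number of compound 2 is particular to thiophen-3-yl or extends to other five-membered rings such as furan-3-yl or thiophen-2-yl.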